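A non-aromatic ring on the saturated chain carbon

The compounds below may be only part of what the source reports. "The series", "measured", "known", "first", "only" and "open" are said of these compounds alone.

Three compounds share one core and differ only in the group on a saturated chain carbon bound to an aromatic carbon and a saturated chain carbon. In an ADME assay on microsomes from liver (Rattus norvegicus) for metabolic stability (on this read-out higher numbers stand for a longer-lived compound and lower numbers for a shorter-lived compound), compound 1 `Cc1nc(C(c2ccc(-c3ccc4cccc(F)c4c3)[nH]c2=O)C(C)C)[nH]c1C` gives 0.0733 h, and compound 2 `CC(C)C(c1nnc[nH]1)c1ccc(-c2ccc3cccc(F)c3c2)[nH]c1=O` gives 0.552 h. Compound 3 `CC(C)C(c1ncc[nH]1)c1ccc(-c2ccc3cccc(F)c3c2)[nH]c1=O` gives only a limit, < 0.0667 h. Its place is the limit of < 0.0667 h in this assay, at which 1 of the 3 values shown sits.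

Compound 4 `CC(C)C(/C=C1/CCNC1=O)c1ccc(-c2ccc3cccc(F)c3c2)[nH]c1=O` keeps the core and takes a new group in the same place: a group of 7 heavy atoms (5 carbon, 1 nitrogen, 1 oxygen; one five-membered non-aromatic ring with 1 hetero atom) in place of a group of 5 heavy atoms (3 carbon, 2 nitrogen; one five-membered aromatic ring with 2 hetero atoms), on a saturated chain carbon bound to an aromatic carbon and a saturated chain carbon.

Among the compounds with values here, three measured steps bear on this change, all of them swaps of the group on that carbon. The series shows a 7.5-fold higher number from compound 1 to compound 2 (0.88 log units; beyond the scatter) and an at least 8.2-fold lower number from compound 2 to compound 3 (0.91 log units; beyond the scatter), both beyond the scatter, while an at least 1.0-fold lower number from compound 1 to compound 3 (0.04 log units; that floor lies within the scatter) stays within it. Within the data shown here, the group on this carbon can therefore shift the half-life considerably, but none of the measured groups holds a non-aromatic ring, so these steps indicate scale and not direction. With compound 3 at its limit, the only open direction is upward. Among the measured compounds shown here, a rise smaller than the one seen for compound 2 at 0.552 h is expected. The expected change is an at least 2.2-fold higher number from compound 3 to compound 4 (0.35 log units; beyond the scatter). For compound 4 the estimated half-life in this assay is 0.15 h, with an expected range from 0.07 h to 0.5 h.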

Compound 4, half-life: 0.06 h
For compound 4 the middle estimate is 2.5-fold (0.40 log units) above the measured one; measured number outside the range, below it.
By their numbers in this assay, from the lowest: compounds 4 and 1 (each within the scatter of the next); then compound 2.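

In this assay, within the data shown here, the non-aromatic ring of compound 4 gives no share of the longer half-life seen with the 4H-1,2,4-triazol-3-yl group on this saturated chain carbon: a 9.2-fold lower number from compound 2 to compound 4 (0.96 log units; beyond the scatter), which leaves compound 2 as the only one of the four compounds whose steps to all the others are printed as beyond the scatter. Set against the 4,5-dimethyl-1H-imidazol-2-yl group, which has the same count of heavy atoms, the new group gives a 1.2-fold lower number from compound 1 to compound 4 (0.09 log units; within the scatter), so an aromatic and a non-aromatic ring cannot be told apart here on this read-out. The step from compound 3 to compound 4 cannot be read, because the value of compound 3 is a limit and not a number: the limit of < 0.0667 h in this assay, at which 1 of the 4 values shown sits.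

The compounds shown leave open whether the half-life of compound 2, 0.552 h, is specific to the triazole or is shared by other five-membered aromatic rings, such as a 1,2,4-oxadiazole or a tetrazole. They also do not tell how the non-aromatic ring would behave without its carbonyl or without the double bond outside it, as in a plain pyrrolidine.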